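Swapping the furan hydrazone for a methylpiperazinylpropyl chain

This account rests on a few compounds, and the source may have more. Where it says the series, first, only, none or still open, it means among the compounds named here.

Of the compounds shown here, three sharing one core have been measured in a functional assay on MDA-MB-231 cells (Homo sapiens) for cytotoxicity, read by MTT assay, with a stated time of 38 h; on this read-out higher numbers stand for weaker inhibition and lower numbers for stronger inhibition. Compound 1 `COc1cc(OC)c2c(=O)c(OCC(=O)N/N=C/c3ccc[nH]3)c(-c3cc(OC)c(OC)c(OC)c3)oc2c1` gives 3750 nM. Compound 2 `COc1cc(OC)c2c(=O)c(OCCCCN3CCCC3)c(-c3cc(OC)c(OC)c(OC)c3)oc2c1` gives 10400 nM. Compound 3 `COc1cc(OC)c2c(=O)c(OCC(=O)N/N=C/c3ccco3)c(-c3cc(OC)c(OC)c(OC)c3)oc2c1` gives 1860 nM, the lowest of the three numbers; the measured steps are a 2.0-fold lower number from compound 1 to compound 3 (0.30 log units; within the scatter) and a 5.6-fold lower number from compound 2 to compound 3 (0.75 log units; beyond the scatter).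

Compound 4 `COc1cc(OC)c2c(=O)c(OCCCCN3CCN(C)CC3)c(-c3cc(OC)c(OC)c(OC)c3)oc2c1` has not yet been measured. It differs from compound 3 in one place: a group of 10 heavy atoms (8 carbon, 2 nitrogen; one six-membered non-aromatic ring with 2 hetero atoms) in place of a group of 10 heavy atoms (6 carbon, 2 nitrogen, 2 oxygen; one five-membered aromatic ring with 1 hetero atom), on a saturated chain carbon bound to an oxygen on an aromatic ring

Within the data shown here, the steps that bear on this change are those in which an aromatic hydrazone tail was exchanged for a chain ending in a saturated nitrogen ring. Going that way gave a 2.8-fold higher number from compound 1 to compound 2 (0.44 log units; beyond the scatter); going the opposite way gave a 5.6-fold lower number from compound 2 to compound 3 (0.75 log units; beyond the scatter). Compound 4 repeats the move toward a saturated amine chain, so a higher number is expected in this assay, of about the size seen for compound 2. The expected step is a 4.3-fold higher number from compound 3 to compound 4 (0.63 log units; beyond the scatter), and compound 4 is estimated at 8000 nM, within a range of 3000 nM to 25000 nM.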

Compound 4, half-maximal inhibitory concentration: 3870 nM
Beside the measured number, compound 4's estimate is 2.1-fold (0.32 log units) above it, within the range that was stated.
By their numbers in this assay, from the lowest: compounds 3, 1 and 4 (each within the scatter of the next, the first and the last beyond it); then compound 2.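

In this assay, a saturated amine chain does not by itself bring the high number of compound 2: changing only the ring at the chain end, to 4-methylpiperazin-1-yl in place of pyrrolidin-1-yl, gives a real gain (a 2.7-fold lower number from compound 2 to compound 4 (0.43 log units; beyond the scatter)). Moving from the furan hydrazone to the 3-(4-methylpiperazin-1-yl)propyl group still costs a modest amount (a 2.1-fold higher number from compound 3 to compound 4 (0.32 log units; beyond the scatter)). Against the pyrrole hydrazone the same group gives no difference that can be told from the scatter (a 1.0-fold higher number from compound 1 to compound 4 (0.01 log units; within the scatter)), so at this position a hydrazone tail and an amine tail can read alike.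

On these data alone, whether a morpholine ring or an open dimethylamine on the same chain would fall nearer compound 4 or compound 2 remains open, as does the effect of a longer chain. No evidence is available on what lies behind these differences.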